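This account rests on a few compounds, and the source may have more. Where it says the series, first, only, none or still open, it means among the compounds named here.

Three measured compounds and one not yet measured share the question of how much of their substitution can be removed. The read-out is a functional assay on HL-60 cells (Homo sapiens) for antiproliferative activity (a higher number here means a weaker inhibitor, a lower number a stronger inhibitor), and the first structure is compound 1 `COc1cc2nccc(O)c2c(O)c1OC`. In this assay compound 1 gives only a limit of the assay, > 30000 nM.

Compound 2 `COc1cc2c(c(OC)c1OC)c(=O)ccn2C` carries a different core, and the difference between the two cores is not broken down here. In this assay compound 2 likewise gives only a limit, > 30000 nM. Compound 3 `COc1cc(OC)c2c(=O)ccn(C)c2c1` differs from compound 2 by one change, (hydrogen in place of methoxy on an aromatic carbon), and in this assay compound 3 also gives only a limit, > 30000 nM. The step that the two limits leave unreadable from compound 2 to compound 3 is therefore unreadable, because the limit of > 30000 nM in this assay, at which 3 of the 3 values shown sit, holds every value shown and nothing above or below it can be told apart.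

The unmeasured structure is compound 4 `COc1cc(O)c2c(O)ccnc2c1`. It differs from compound 1 by hydrogen in place of methoxy on an aromatic carbon, the same kind of change as that from compound 2 to compound 3, though the surroundings differ: in compound 2 the carbon is ortho to two methoxy groups, while in compound 1 it is ortho to a hydroxy group and ortho to a methoxy group. The expected step that the limit leaves unreadable from compound 1 to compound 4 is set beside the unreadable a step that the two limits leave unreadable from compound 2 to compound 3, and it rests only on compound 1 sitting at > 30000 nM with no readable movement anywhere in the set. Compound 4 is thus estimated to give 50000 nM in this assay, most probably again as a limit rather than a number.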

Compound 4, half-maximal inhibitory concentration: > 30000 nM
Compound 4: no number, only a limit; the forecaster's own chance of this, stated with the estimate: 85%; the middle value lies beyond the limit too.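

Compound 4 gives > 30000 nM in this assay, which is a limit of the assay and not a number. No step can be read from compound 1 to compound 4, because neither compound has a number to compare: the limit of > 30000 nM in this assay, at which 4 of the 4 values shown sit. The compounds shown leave open whether removing a methoxy group changes activity at all, and how these four structures would rank against one another.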